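The source may hold more compounds than are shown below. What is called first, only, known or untested is meant among the compounds shown, and "the series" means these compounds.

Measured so far in an ADME assay on MCF-10A cells (Homo sapiens) for cytotoxicity, read by MTT assay, with a stated time of 24 h; a higher number here means a weaker inhibitor, a lower number a stronger inhibitor: compound 1 `Fc1ccc(-n2cc(COc3ccccc3-c3nc4ccccc4s3)nn2)cc1` gives 33300 nM; compound 2 `Brc1ccc(-c2cc(COc3ccccc3-c3nc4ccccc4s3)on2)cc1` gives 29200 nM; compound 3 `c1ccc(-n2cc(COc3ccccc3-c3nc4ccccc4s3)nn2)cc1` gives 36400 nM.

Compound 2 shows the lowest number of the three, yet compound 1 and compound 3 both lie within the scatter of it, so no order among them can be claimed. Compound 4 `Clc1ccc(-c2cc(COc3ccccc3-c3nc4ccccc4s3)on2)cc1` differs from compound 2 by chloro in place of bromo on an aromatic carbon. Going by the values given here, the one measured step on the same kind of ring, a 1.1-fold higher number from compound 1 to compound 3 (0.04 log units; within the scatter), exchanges a halogen for hydrogen and stays within the scatter; no measured pair exchanges one halogen for another. On that basis, the step expected from compound 2 to compound 4 is a 1.0-fold lower number from compound 2 to compound 4 (0.00 log units; within the scatter), nothing beyond the scatter. Compound 4 is therefore estimated at 29000 nM, between 15000 nM and 58000 nM.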

Compound 4, half-maximal inhibitory concentration: 38800 nM
For compound 4 the middle estimate is 1.3-fold (0.13 log units) below the measured one; measured number inside the range.
By their numbers in this assay, from the lowest: compounds 2, 1, 3 and 4 (each within the scatter of the next).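

In this assay, the exchange of bromo for chloro on an aromatic carbon, para to a large group, gives a 1.3-fold higher number from compound 2 to compound 4 (0.12 log units; within the scatter) and so stays within the scatter. Going by these compounds alone, this is the first measured exchange of one halogen for another, and it shows that, on the core of compound 2, these two halogens cannot be told apart in this read-out. No evidence here bears on this result. Still open, from the compounds shown here alone, is whether an amine, a carboxylic acid or a methoxy group at this place would give a step beyond the scatter.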